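This account rests on a few compounds, and the source may have more. Where it says the series, first, only, none or still open, it means among the compounds named here.

Measured compounds:
Compound 1 `Cc1ccc2ccc(-c3cccc(C#N)c3)cc2n1` gives 7.7 nM in a functional assay on CHO cells for inhibition of metabotropic glutamate receptor 5 (Rattus norvegicus), read by FLIPR and calcium flux; a lower number here means a stronger inhibitor, a higher number a weaker inhibitor.
Compound 2 `Cc1ccc2ccc(-c3cccc(O)c3)cc2n1` gives 19000 nM in this assay.

Among the measured compounds shown here, only two compounds have been measured, and compound 1 stands at the lower of the two numbers, which here means the stronger inhibitor. For the measured compounds named here, the single step between them, a 2500-fold higher number from compound 1 to compound 2 (3.39 log units; beyond the scatter), came from swapping the nitrile for a hydroxy group on the pendant ring, and it was a very large step toward weaker inhibition.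

Compound 3 `Cc1ccc2ccc(-c3cc(F)cc(C#N)c3)cc2n1` keeps the nitrile and differs from compound 1 only by fluoro in place of hydrogen on an aromatic carbon, the new fluorine sitting on the same six-membered ring of carbon only, meta to a cyano group. Going by the values given here, no measured step matches this change, since the one known step replaced the nitrile itself rather than adding a small substituent beside it. Among the compounds with values here, that step therefore shows only that the pendant ring matters a great deal; it gives no direction for a fluoro addition. For compound 3 the expectation is a 1.2-fold higher number from compound 1 to compound 3 (0.07 log units; within the scatter), a change not beyond the scatter. Compound 3 is estimated at 9 nM, with a range from 3 nM to 30 nM.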

Compound 3, half-maximal inhibitory concentration: 0.8 nM
Estimate against measurement, compound 3: 11-fold (1.05 log units) above; the measured number lies below the stated range.
By their numbers in this assay, from the lowest: compound 3; then compound 1; then compound 2.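

Fluoro in place of hydrogen on an aromatic carbon, meta to a cyano group, gives a 9.6-fold lower number from compound 1 to compound 3 (0.98 log units; beyond the scatter) and so moves toward stronger inhibition, a modest step but a real one. Among the compounds shown here, the only earlier step on this six-membered aromatic ring of carbon only replaced the nitrile itself and went a long way toward weaker inhibition, whereas compound 3 shows that adding a single fluorine while keeping the nitrile can go in the opposite direction. Nothing available here accounts for this gain.

The compounds shown leave open whether the gain is specific to fluoro, since chloro, methyl or methoxy at the same place would be needed to tell, and whether fluoro on a different carbon of this ring would do the same. They also leave open whether the fluoro still helps when the nitrile is replaced, for instance by an amine or a carboxylic acid, and whether any such replacement can keep inhibition as strong as that of compound 1.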